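Pyridin-3-yl for 3,4-dimethylphenyl on the hydrazone nitrogen

A few compounds are considered here, and "the series" means these few. Any claim that something is new, unique, unknown or untested is made for them only; others in the source may bear on it.

This account follows the step from compound 1 to compound 3. Compound 1 `Cc1ccc(NN=C2CCC(C)n3c2ncc(C(=O)O)c3=O)cc1C` gives in a functional assay on the whole organism with Rattus norvegicus as the target (on this read-out lower numbers stand for an effect already at smaller amounts and higher numbers for an effect only at larger amounts of compound), only the limit > 100 umol/kg, which is a limit of the assay and not a number (the limit of > 100 umol/kg in this assay, at which 1 of the 2 values shown sits). Compound 2 `Cc1cc(C)c(NN=C2CCC(C)n3c2ncc(C(=O)O)c3=O)cc1C` gives in this assay the value 320 umol/kg. Within the data shown here, the one measured step, a step that the limit leaves unreadable from compound 1 to compound 2, stays unreadable, so no measured step tells how far a change on this part of the molecule moves the read-out. Compound 3 `CC1CCC(=NNc2cccnc2)c2ncc(C(=O)O)c(=O)n21` carries pyridin-3-yl in place of 3,4-dimethylphenyl on an amine nitrogen. Among the measured compounds shown here, since the only comparison starts from a limit, no size or direction can be drawn from the measured compounds for this change. For the measured compounds named here, the author therefore expects compound 3 to sit near 250 umol/kg, within the range 60 umol/kg to 1000 umol/kg, as a guess centred where the one numeric value in this assay lies. The step is expected to be a step that the limit leaves unreadable from compound 1 to compound 3.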

Compound 3, dose for 50% inhibition: > 320 umol/kg
Compound 3: no number, only a limit; the forecaster's own chance of this, stated with the estimate: 40%; at least 1.2-fold (0.10 log units) between middle value and limit.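

Compound 1 and compound 3 each give only a limit of the assay, so the step between them cannot be read. The compounds shown leave open how far pyridin-3-yl in place of 3,4-dimethylphenyl on an amine nitrogen moves the read-out in this assay.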